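The compounds below may be only part of what the source reports. "The series", "measured", "known", "first", "only" and "open" are said of these compounds alone.

Measured in a functional assay on A-375 cells (Homo sapiens) for cytotoxicity, read by MTT assay, with a stated time of 72 h; a higher number here means a weaker inhibitor, a lower number a stronger inhibitor:

Compound 1 `Cc1cccc(/C(N)=N/NC(=S)N2CCN(c3ccccn3)CC2)n1`: 850 nM
Compound 2 `N/C(=N\NC(=S)N1CCN(c2ccccn2)CC1)c1ccc(F)cn1`: 1400 nM
Compound 3 `Cc1cccc(/C(N)=N/NC(=S)N2CCSCC2)n1`: 1400 nM

Compound 3 stands level with compound 2 at the digits given, and its gap to compound 1 lies within the scatter, so the three numbers cannot be ranked against each other.

Compound 4 `Cc1cccc(/C(N)=N/NC(=S)N2CCCCC2)n1` is not yet measured. It differs from compound 3 in one place: piperidin-1-yl in place of thiomorpholin-4-yl on a thiocarbonyl carbon.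

Among the compounds with values here, the only step measured, a 1.6-fold higher number from compound 1 to compound 2 (0.22 log units; within the scatter), concerns the group attached to the carbon with a double bond to nitrogen, not the ring on the thiocarbonyl carbon, so it does not bear on the change to compound 4. Within the data shown here, compound 1 and compound 3 differ in the ring on the thiocarbonyl carbon, and their two values lie within the scatter of each other; no step is computed for that pair. Exchanging one six-membered non-aromatic ring for another at this position has therefore produced nothing beyond the scatter in the shared core, and the expected step of no change at the digits printed from compound 3 to compound 4 (within the scatter) is likewise none beyond the scatter. For compound 4 the estimate in this assay is 1400 nM, with a range from 600 nM to 3500 nM.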

Compound 4, half-maximal inhibitory concentration: 1000 nM
The estimate for compound 4 lay 1.4-fold (0.15 log units) above the measured number; low and high end bracket the measured number.
By their numbers in this assay, from the lowest: compounds 1, 4, 2 and 3 (each within the scatter of the next).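

In this assay, within the data shown here, piperidin-1-yl in place of thiomorpholin-4-yl on the thiocarbonyl carbon gives a 1.4-fold lower number from compound 3 to compound 4 (0.15 log units; within the scatter) and is the first one-place step read directly at this position. The ring sulfur and the hydrogen-bond acceptor counted with it can therefore go, at an unchanged count of heavy atoms, without a shift beyond the scatter in this cytotoxicity read-out, at least on the shared core with 6-methylpyridin-2-yl on the carbon with a double bond to nitrogen. No measurement shown explains why the read-out stays within the scatter across this change.

Among these compounds, every comparison at this position so far involves a six-membered non-aromatic ring or a group built on one, and none shows a step beyond the scatter, so it remains open whether an open-chain dimethylamino group, or a piperidine ring bearing a carboxylic acid, would shift the number. Going by these compounds, it is also open whether the same exchange gives a similar result when 5-fluoropyridin-2-yl takes the place of 6-methylpyridin-2-yl on the carbon with a double bond to nitrogen.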